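The source may hold more compounds than are shown below. What is called first, only, known or untested is meant among the compounds shown, and "the series" means these compounds.

Compound 1 `COC(=O)[C@@]1(C)CC[C@@H]2C3=C1CC[C@@H](C)[C@]3(C)C[C@@H]1c3ccccc3N[C@H]21` has the highest number of the three measured compounds in a functional assay on HBL-100 cells (Homo sapiens) for inhibition, read by sulforhodamine B assay, with a stated time of 48 h (a lower number here means a stronger inhibitor of growth, a higher number a weaker inhibitor of growth), with 78000 nM. Compound 2 `COC(=O)[C@@]1(C)CC[C@@H]2C3=C1CC[C@@H](C)[C@]3(C)C[C@@H]1c3cc(Br)ccc3N[C@H]21` gives 34000 nM and compound 3 `COC(=O)[C@@]1(C)CC[C@@H]2C3=C1CC[C@@H](C)[C@]3(C)C[C@@H]1c3cc(OC)ccc3N[C@H]21` gives 15000 nM. The step to compound 4 `COC(=O)[C@@]1(C)CC[C@@H]2C3=C1CC[C@@H](C)[C@]3(C)C[C@@H]1c3cccc(Cl)c3N[C@H]21` is chloro in place of hydrogen on an aromatic carbon. The measured steps that bear on it are other single substitutions on the same aromatic ring, at a different place: a 2.3-fold lower number from compound 1 to compound 2 (0.36 log units; beyond the scatter) and a 5.2-fold lower number from compound 1 to compound 3 (0.72 log units; beyond the scatter), both lowering the number beyond the scatter. A halogen at a new place is expected to give at most a modest step downward, if any, so compound 4 is estimated at 45000 nM, in the range 15000 nM to 110000 nM. This estimate means a 1.7-fold lower number from compound 1 to compound 4 (0.24 log units; within the scatter), a step of uncertain size given that only bromo and methoxy were measured.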

Compound 4, concentration for 50% growth inhibition: 52000 nM
Compound 4: middle estimate off by 1.2-fold (0.06 log units), on the low side; the range from low to high includes it.
By their numbers in this assay, from the lowest: compound 3; then compounds 2, 4 and 1 (each within the scatter of the next, the first and the last beyond it).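

In this assay, chloro in place of hydrogen on this aromatic carbon, ortho to a fused ring and meta to a fused ring, gives a 1.5-fold lower number from compound 1 to compound 4 (0.18 log units; within the scatter) and so stays within the scatter, whereas the bromo and methoxy steps at another place on the same ring went beyond it. This single substitution therefore shows no clear change at this position. Nothing shown here offers an explanation for this result. The compounds shown leave open whether an amine or methoxy at this place would move the number beyond the scatter, and how chloro would read at the place that carries bromo in compound 2.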